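Thiazole Isomer Swap in an mGlu5 Potentiator Series

The compounds below may be only part of what the source reports. "The series", "measured", "known", "first", "only" and "open" are said of these compounds alone.

Compound 1 `O=C(COCc1ccccc1)N1CCN(c2ccc(Cl)cc2Cl)CC1`: 1000 nM
Compound 2 `O=C(COCc1cscn1)N1CCN(c2ccc(Cl)cc2Cl)CC1`: 290 nM

In a functional assay on HEK293 cells for positive allosteric modulation of metabotropic glutamate receptor 5 (Homo sapiens), read by FLIPR and calcium flux (a higher number here means that more compound is needed for the effect, a lower number that less compound is needed), compound 2 gives the lowest of the two numbers measured; its nearest neighbour is compound 1, at a 3.4-fold lower number from compound 1 to compound 2 (0.54 log units; beyond the scatter). Compound 3 `O=C(COCc1cncs1)N1CCN(c2ccc(Cl)cc2Cl)CC1` differs from compound 2 by 1,3-thiazol-5-yl in place of 1,3-thiazol-4-yl on a saturated chain carbon bound to an oxygen on a saturated carbon. For the measured compounds named here, no measured step bears on this isomer change; the single step from a phenyl group to the thiazolyl group, of the size just given, does not tell how the two thiazolyl isomers compare. Compound 3 is therefore expected to give 350 nM, in the range 150 nM to 900 nM, a step of a 1.2-fold higher number from compound 2 to compound 3 (0.08 log units; within the scatter) that is not expected to exceed the scatter.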

Compound 3, half-maximal effective concentration: 1280 nM
For compound 3 the middle estimate is 3.7-fold (0.56 log units) below the measured one; the measured number lies above the stated range.
By their numbers in this assay, from the lowest: compound 2; then compounds 1 and 3 (each within the scatter of the next).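

In this assay, the place on a saturated chain carbon bound to an oxygen on a saturated carbon proves sensitive to how the thiazole is attached: 1,3-thiazol-5-yl in place of 1,3-thiazol-4-yl gives a 4.4-fold higher number from compound 2 to compound 3 (0.64 log units; beyond the scatter) despite identical atoms and counts. The lower number seen with 1,3-thiazol-4-yl therefore does not extend to both isomers, as phenyl to 1,3-thiazol-5-yl gives a 1.3-fold higher number from compound 1 to compound 3 (0.11 log units; within the scatter) and stays inside the scatter. Nothing given here explains the split between the isomers. Going by these compounds, how a 1,3-thiazol-2-yl or a pyridin-2-yl group would behave at this place remains open.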